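Aryl variation on a shared core: expectation for compound 4

The source may report more compounds than this note shows. Statements on the series, on what has been measured and on what is new or still open speak of the compounds shown alone.

Three compounds share one core and differ only in the aryl group on a double-bonded chain carbon bound to a double-bonded chain carbon and a saturated chain carbon. In a functional assay on MCF7 cells (Homo sapiens) for inhibition (on this read-out higher numbers stand for weaker inhibition and lower numbers for stronger inhibition), compound 1 `CC/C(=C(/c1ccc(/C=C/C(=O)O)cc1)c1cc2ccccc2[nH]1)c1ccccc1OC(F)(F)F` gives 206 nM. Compound 2 `CC/C(=C(/c1ccc(/C=C/C(=O)O)cc1)c1cc2ccccc2[nH]1)c1cccc(OC(F)(F)F)c1` gives 282 nM in this assay, and compound 3 `CC/C(=C(/c1ccc(/C=C/C(=O)O)cc1)c1cc2ccccc2[nH]1)c1ccc(C#N)cc1` gives 278 nM in this assay. The steps are a 1.4-fold higher number from compound 1 to compound 2 (0.14 log units; within the scatter), a 1.3-fold higher number from compound 1 to compound 3 (0.13 log units; within the scatter) and a 1.0-fold lower number from compound 2 to compound 3 (0.01 log units; within the scatter), so compound 3 sits with compound 2 and compound 1 without any separation beyond the scatter.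

Compound 4 `CC/C(=C(/c1ccc(/C=C/C(=O)O)cc1)c1cc2ccccc2[nH]1)c1ccc(Cl)cc1C#N` has not been measured in this assay. It differs from compound 3 in one place: 4-chloro-2-cyanophenyl in place of 4-cyanophenyl on a double-bonded chain carbon bound to a double-bonded chain carbon and a saturated chain carbon.

Within the data shown here, both steps that end at compound 3, a 1.3-fold higher number from compound 1 to compound 3 (0.13 log units; within the scatter) and a 1.0-fold lower number from compound 2 to compound 3 (0.01 log units; within the scatter), exchange the whole aryl group and stay within the scatter; no step changes one substituent on the aryl ring while keeping another. The expectation for this assay is therefore a step of no more than the scatter in either direction, and compound 4 is estimated at 280 nM with a range from 130 nM to 600 nM. This estimate means an expected step of a 1.0-fold higher number from compound 3 to compound 4 (0.00 log units; within the scatter).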

Compound 4, half-maximal inhibitory concentration: 14 nM
For compound 4 the middle estimate is 20-fold (1.30 log units) above the measured one; the measured number lies below the stated range.
By their numbers in this assay, from the lowest: compound 4; then compounds 1, 3 and 2 (each within the scatter of the next).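

Working notes: in this assay this aryl position proves responsive, with a 20-fold lower number from compound 3 to compound 4 (1.30 log units; beyond the scatter) and a 20-fold lower number from compound 2 to compound 4 (1.30 log units; beyond the scatter) and also a 15-fold lower number from compound 1 to compound 4 (1.17 log units; beyond the scatter) all beyond the scatter, so compound 4 is the strongest inhibitor of the four. The exchanges among 2-(trifluoromethoxy)phenyl, 3-(trifluoromethoxy)phenyl and 4-cyanophenyl had stayed within the scatter, so those three groups gave no sign of this range, which appears only with 4-chloro-2-cyanophenyl. The change from compound 3 to compound 4 adds a chlorine and also places the nitrile differently on the ring, and nothing available here explains the large step.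

The two parts of that change remain unseparated: a 4-chlorophenyl group and a 2-cyanophenyl group, each on the same double-bonded chain carbon, would show whether the chlorine, the nitrile placement or only their combination carries the step. Also open, as far as these compounds go, is how specific the chlorine is, which a 4-fluoro-2-cyanophenyl or 4-bromo-2-cyanophenyl group at this place would address.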